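Swapping a heptyl tail for a morpholine dithiocarbamate

The source may hold more compounds than are shown below. What is called first, only, known or untested is meant among the compounds shown, and "the series" means these compounds.

Measured so far in a functional assay on A549 cells (Homo sapiens) for inhibition, read by MTT assay, with a stated time of 72 h; a lower number here means a stronger inhibitor, a higher number a weaker inhibitor:
- compound 1 `O=c1cc(Cn2cc(CCCO)nn2)c2ccc(O)cc2o1`: 96200 nM
- compound 2 `O=c1cc(Cn2cc(CCCCO)nn2)c2ccc(O)cc2o1`: > 100000 nM
- compound 3 `CCCCCCCCc1cn(Cc2cc(=O)oc3cc(O)ccc23)nn1`: 46000 nM

Compound 2 reaches only a limit of this assay, so its result is not a number (the limit of > 100000 nM in this assay, at which 1 of the 3 values shown sits). Among the two numbers, compound 3 stands lowest; its nearest neighbour is compound 1, and the step of a 2.1-fold lower number from compound 1 to compound 3 (0.32 log units; beyond the scatter) is modest. The step of an at least 1.0-fold higher number from compound 1 to compound 2 (0.01 log units; that floor lies within the scatter) lies within the scatter, while an at least 2.1-fold lower number from compound 2 to compound 3 (0.33 log units; beyond the scatter) is at least modest. All three measured steps exchange a hydroxy on the chain for an alkyl or a longer alcohol, and none of them touches a sulfur-containing group.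

Compound 4 `O=c1cc(Cn2cc(CSC(=S)N3CCOCC3)nn2)c2ccc(O)cc2o1` differs from compound 3 by a group of 9 heavy atoms (5 carbon, 1 nitrogen, 1 oxygen, 2 sulfur; one six-membered non-aromatic ring with 2 hetero atoms) in place of a group of 7 heavy atoms (7 carbon; no ring), on a saturated chain carbon bound to an aromatic carbon. Going by the values given here, no measured step resembles this exchange, so the expectation rests only on the narrow spread seen so far. For compound 4 a step of a 1.3-fold lower number from compound 3 to compound 4 (0.12 log units; within the scatter) is expected, that is no clear change beyond the scatter, and in this assay compound 4 is estimated at 35000 nM, within 6000 nM to 100000 nM.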

Compound 4, half-maximal inhibitory concentration: 70200 nM
Compound 4: the middle estimate sits 2.0-fold (0.30 log units) below what was measured; low and high end bracket the measured number.
By their numbers in this assay, from the lowest: compounds 3, 4 and 1 (each within the scatter of the next, the first and the last beyond it). At a limit, above all of these: compound 2.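

In this assay, putting the morpholine dithiocarbamate group, with its six-membered ring and two sulfur atoms, in place of heptyl gives a 1.5-fold higher number from compound 3 to compound 4 (0.18 log units; within the scatter), so this large exchange on the saturated chain carbon brings no clear change. The comparison with the short alcohol gives a 1.4-fold lower number from compound 1 to compound 4 (0.14 log units; within the scatter), also no clear change, so compound 4 cannot be ranked against compound 3 or compound 1, even though those two differ beyond the scatter. The step of an at least 1.4-fold lower number from compound 2 to compound 4 (0.15 log units; that floor lies within the scatter) starts from a limit rather than a number and shows no clear change either: the limit of > 100000 nM in this assay, at which 1 of the 4 values shown sits.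

The compounds shown do not separate the part played by the morpholine ring from that of the dithiocarbamate. A piperidine dithiocarbamate, or a simple amine or carboxylic acid on the same carbon, would help to tell these apart.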